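The source may report more compounds than this note shows. Statements on the series, on what has been measured and on what is new or still open speak of the compounds shown alone.

Compound 1, `COc1ccc(C(=O)/C=C/c2ccc(F)cc2)c(O)c1`, gives 21900 nM in a functional assay on T47D cells (Homo sapiens) for cytotoxicity, read by MTT assay; a higher number here means a weaker inhibitor, a lower number a stronger inhibitor.
Compound 2, `COc1ccc(C(=O)/C=C/c2ccc(OC)c(Br)c2)c(O)c1`, has no number in this assay; the entry reads "not determined" (no result reported).
Compound 3, `O=C(/C=C/c1ccc(F)cc1)c1ccc(O)cc1O`, gives 8310 nM in this assay.
Compound 4, `COc1ccc(/C=C/C(=O)c2ccc(O)cc2O)cc1Br`, has not been measured yet.

For the measured compounds named here, all four compounds share the same core, and the only structural change followed here is a small one on that core. From compound 1 to compound 3 the change is hydrogen in place of methyl on an oxygen on an aromatic ring. The same change, at the same kind of place, separates compound 2 from compound 4: hydrogen in place of methyl on an oxygen on an aromatic ring. The place lines read the same, so this is the same change made twice. How compound 2 differs from compound 1, in the other half of the molecule, is not broken down here.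

The measured pair shows the step this change made: a 2.6-fold lower number from compound 1 to compound 3 (0.42 log units; beyond the scatter). That is a step beyond the usual scatter of repeated measurements in this assay, but a modest one.

For compound 2 no number exists, so the same step cannot be applied to a starting value. What remains is the result for the other compound carrying the hydroxy form of the core, compound 3, which gives 8310 nM, and the direction of the step from compound 1 to compound 3 in this assay. Going by the values given here, on that footing compound 4 is expected to land near compound 3, with a wide margin because only one value on this core, 8310 nM, is known. The estimate for compound 4 in this assay is 8000 nM, expected to fall between 2500 nM and 25000 nM.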

Compound 4, half-maximal inhibitory concentration: 1050 nM
For compound 4 the middle estimate is 7.6-fold (0.88 log units) above the measured one, outside the stated range (below it).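

For the compounds shown here, compound 2 has no single number in this assay to start from, so the step to compound 4 cannot be read and the result for compound 4 adds no new step. The compounds shown leave open whether methoxy to hydroxy on compound 2 would match the size of a 2.6-fold lower number from compound 1 to compound 3 (0.42 log units; beyond the scatter) or differ from it. Nothing available here bears on the reason for this result.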